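Moving a methoxy group on the dimethoxyphenyl ring

The source may hold more compounds than are shown below. What is called first, only, known or untested is meant among the compounds shown, and "the series" means these compounds.

In a functional assay on A549 cells (Homo sapiens) for inhibition, read by MTT assay, with a stated time of 48 h (a higher number here means a weaker inhibitor, a lower number a stronger inhibitor), compound 3 (`COc1cccc(C(c2c[nH]c3ccc(Br)cc23)c2c[nH]c3ccc(Br)cc23)c1OC`) gives 100000 nM as the highest of the three measured numbers, which makes it the weakest inhibitor so far. Compound 1 (`Oc1ccc(C(c2c[nH]c3ccc(Br)cc23)c2c[nH]c3ccc(Br)cc23)cc1`) gives 9000 nM and compound 2 (`Oc1cccc(C(c2c[nH]c3ccc(Br)cc23)c2c[nH]c3ccc(Br)cc23)c1`) gives 8000 nM in the same read-out. Compound 4 (`COc1ccc(C(c2c[nH]c3ccc(Br)cc23)c2c[nH]c3ccc(Br)cc23)c(OC)c1`) carries 2,4-dimethoxyphenyl in place of 2,3-dimethoxyphenyl on a saturated chain carbon bound to two aromatic carbons and is still unmeasured. Within the data shown here, the closest precedent relocates a hydroxy group, with a 1.1-fold lower number from compound 1 to compound 2 (0.05 log units; within the scatter) and no shift beyond the scatter. The steps of an 11-fold higher number from compound 1 to compound 3 (1.05 log units; beyond the scatter) and a 13-fold higher number from compound 2 to compound 3 (1.10 log units; beyond the scatter) are large but exchange hydroxyphenyl for dimethoxyphenyl, and compound 4 remains a dimethoxyphenyl compound. Among the measured compounds shown here, no measured pair compares two dimethoxyphenyl isomers, so no step beyond the scatter is expected. The estimated step is a 1.4-fold lower number from compound 3 to compound 4 (0.15 log units; within the scatter) in this assay with wide uncertainty. For compound 4 the estimated value is 70000 nM within an expected range of 20000 nM to 150000 nM on current data.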

Compound 4, half-maximal inhibitory concentration: 100000 nM
The estimate for compound 4 lay 1.4-fold (0.15 log units) below the measured number; low and high end bracket the measured number.
By their numbers in this assay, from the lowest: compounds 2 and 1 (each within the scatter of the next); then compounds 3 and 4 (each within the scatter of the next).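

In this assay, among these compounds, the first comparison of two dimethoxyphenyl isomers on this carbon gives no change at the digits printed from compound 3 to compound 4 (within the scatter), so relocating this methoxy group leaves the number unchanged. The large gap to the hydroxyphenyl compounds also recurs with the 2,4-dimethoxyphenyl group, with a 13-fold higher number from compound 2 to compound 4 (1.10 log units; beyond the scatter) and an 11-fold higher number from compound 1 to compound 4 (1.05 log units; beyond the scatter). Open, on these data alone, is whether a single methoxy group or an aminophenyl group on this carbon would give numbers near those of compound 1 and compound 2 or near those of compound 3 and compound 4. No available data explain the gap between the hydroxyphenyl and dimethoxyphenyl compounds.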